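The source may hold more compounds than are shown below. What is called first, only, known or untested is meant among the compounds shown, and "the series" means these compounds.

Working notes on the series. Three compounds have numbers in an assay on isolated protein for inhibition of Neprilysin (Oryctolagus cuniculus); a lower number here means a stronger inhibitor, a higher number a weaker inhibitor. Compound 1 `Cc1ccccc1[C@H]1CC[C@H](C(=O)O)N1C(=O)CNC(=O)[C@@H](S)Cc1ccccc1` gives 25 nM in this assay. Compound 2 `Cc1ccc([C@H]2CC[C@@H](C(=O)O)N2C(=O)CNC(=O)[C@@H](S)Cc2ccc(O)cc2)cc1` gives 5.5 nM in this assay. Compound 3 `O=C(NCC(=O)N1[C@@H](c2cccc(O)c2)CC[C@H]1C(=O)O)[C@@H](S)Cc1cccc(O)c1` gives 4.3 nM in this assay. Compound 2 thus stands second highest of the three numbers; its gap to compound 3 lies within the scatter, while compound 1 gives a higher number, beyond the scatter. Compound 4 `Nc1ccc([C@H]2CC[C@@H](C(=O)O)N2C(=O)CNC(=O)[C@@H](S)Cc2ccc(O)cc2)cc1` is not yet measured in this assay. It differs from compound 2 by amino in place of methyl on an aromatic carbon. Among the measured compounds shown here, no step of this kind is available among the measured compounds, so the step from compound 2 to compound 4 is expected to be small, a 1.1-fold higher number from compound 2 to compound 4 (0.04 log units; within the scatter), with no direction beyond the scatter. Compound 4 is estimated at 6 nM, within 2 nM to 18 nM.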

Compound 4, half-maximal inhibitory concentration: 26 nM
Compound 4: the middle estimate sits 4.3-fold (0.64 log units) below what was measured; measured number outside the range, above it.
By their numbers in this assay, from the lowest: compounds 3 and 2 (each within the scatter of the next); then compounds 1 and 4 (each within the scatter of the next).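

In this assay, among the compounds shown here, the position para to a large group responds to its substituent: going from 4-methylphenyl to 4-aminophenyl gives a 4.7-fold higher number from compound 2 to compound 4 (0.67 log units; beyond the scatter) and is the first single-place step. One heavy atom exchanged, with one hydrogen-bond donor and one acceptor entering, is enough to move the number beyond the scatter. Nothing at hand accounts for this step.

Open, as far as these compounds go, is whether a methoxy group or an acetamide at the same position would track the methyl or the amino. Also open, from the compounds shown here alone, is whether the step holds with other groups elsewhere on the shared core.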